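Lengthening One Ester Chain: Compounds 1 to 4

The source may report more compounds than this note shows. Statements on the series, on what has been measured and on what is new or still open speak of the compounds shown alone.

Compound 1 `CCOC(=O)C1=C(C)NC(C)=C(C(=O)OC)C1c1csc(-c2ccc(Cl)cc2)n1`: 22000 nM
Compound 2 `CCCOC(=O)C1=C(C)NC(C)=C(C(=O)OC)C1c1csc(-c2ccc(Cl)cc2)n1`: 5920 nM
Compound 3 `COC(=O)C1=C(C)NC(C)=C(C(=O)OC(C)(C)C)C1c1csc(-c2ccc(Cl)cc2)n1`: 46000 nM

These three compounds were tested in an assay on isolated protein for antagonist activity at Voltage-dependent L-type calcium channel subunit alpha-1C (Cavia porcellus), with a stated time of 15 min; on this read-out lower numbers stand for stronger inhibition and higher numbers for weaker inhibition. Compound 4 `CCOC(=O)C1=C(C)NC(C)=C(C(=O)OC(C)(C)C)C1c1csc(-c2ccc(Cl)cc2)n1` has not yet been measured. Compound 4 differs from compound 3 by methyl in place of hydrogen on a saturated chain carbon bound to an oxygen next to a carbonyl group. The same kind of change has been measured once already: compound 2 differs from compound 1 by methyl in place of hydrogen on a saturated chain carbon, two bonds along the chain from an oxygen next to a carbonyl group, and this gave a 3.7-fold lower number from compound 1 to compound 2 (0.57 log units; beyond the scatter). The two places are not identical: in the measured pair the methyl enters two bonds along the chain from an oxygen next to a carbonyl group, whereas in the new pair it enters on a saturated chain carbon bound to that oxygen. The cores of compound 1 and compound 3 also differ, by tert-butyl in place of ethyl on an oxygen next to a carbonyl group, which gave a 2.1-fold higher number from compound 1 to compound 3 (0.32 log units; beyond the scatter). For compound 4 a step of a 2.6-fold lower number from compound 3 to compound 4 (0.41 log units; beyond the scatter) in this assay is expected, resting on a 3.7-fold lower number from compound 1 to compound 2 (0.57 log units; beyond the scatter) and tempered by the difference in place. Compound 4 is therefore estimated at 18000 nM, with a likely range from 8000 nM to 40000 nM.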

Compound 4, half-maximal inhibitory concentration: 91000 nM
For compound 4 the middle estimate is 5.1-fold (0.70 log units) below the measured one; measured number outside the range, above it.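

In this assay the same added methyl does not behave alike on the two cores: the same change on two cores in this assay, a 3.7-fold lower number (0.57 log units; beyond the scatter) from compound 1 to compound 2 and a 2.0-fold higher number (0.30 log units; within the scatter) from compound 3 to compound 4, 7.4-fold (0.87 log units) apart, beyond the scatter of two such steps

On the core of compound 3 the change gives a 2.0-fold higher number from compound 3 to compound 4 (0.30 log units; within the scatter), so the lower number seen on the core of compound 1 does not carry over. For the compounds shown here, each core offers only one pair, and the methyl enters at a different place in each, so these data cannot separate an effect of the core from an effect of the place. Replacing methyl with tert-butyl on the other ester, a separate change, gives a 4.1-fold higher number from compound 1 to compound 4 (0.62 log units; beyond the scatter).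

The compounds shown leave open how a longer chain such as butyl, or a chain ending in an amine, would behave on either core.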